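The source may report more compounds than this note shows. Statements on the series, on what has been measured and on what is new or still open speak of the compounds shown alone.

Among the measured compounds shown here, only two compounds have a number so far in a functional assay on HeLa cells (Homo sapiens) for antiproliferative activity, read by MTT assay, with a stated time of 72 h; a higher number here means a weaker inhibitor, a lower number a stronger inhibitor. In this test compound 1 (`COc1ncc(-c2ccc3c(c2)N(C2CCCCC2)C(=O)CO3)cc1NS(=O)(=O)c1ccc(F)cc1`) gives 6100 nM and compound 2 (`COc1cccc(N2C(=O)COc3ccc(-c4cnc5ccccc5c4)cc32)c1`) gives 11400 nM as its half-maximal inhibitory concentration. Compound 2 therefore cannot be told apart from compound 1, as the two values lie within the usual scatter of repeated measurements.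

Compound 3 (`COc1ccc(N2C(=O)COc3ccc(-c4cnc5ccccc5c4)cc32)cc1`) has not yet been measured. It carries 4-methoxyphenyl in place of 3-methoxyphenyl on an amide-type nitrogen in a ring and otherwise keeps the core of compound 2 unchanged.

For the measured compounds named here, no measured pair in this small set differs in one place only, so the data hold no precedent for a swap of this kind. The expectation therefore rests on the close likeness of the two structures, and no shift beyond the scatter is expected in either direction. The estimated change (a 1.1-fold lower number from compound 2 to compound 3 (0.06 log units; within the scatter)) is accordingly small. For compound 3 the estimated value in this assay is 10000 nM with a range from 3500 nM to 30000 nM expected.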

Compound 3, half-maximal inhibitory concentration: > 40000 nM
Compound 3 gave a limit, no number (the forecaster's own chance of this, stated with the estimate: 10%); middle value at least 4.0-fold (0.60 log units) from the limit.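

In this assay, putting 4-methoxyphenyl in place of 3-methoxyphenyl on the amide-type nitrogen in a ring gives an at least 3.5-fold higher number from compound 2 to compound 3 (0.54 log units; beyond the scatter). Among the compounds shown here, this is the first step in the set that changes one place only, and it shows that the result at this nitrogen depends on where the methoxy group stands on the phenyl ring, even though the group that leaves and the group that enters have the same atoms and the same counts of donors and acceptors. For compound 3 the read-out is a limit of the assay and not a number, so the step gives a minimum size only: the limit of > 40000 nM in this assay, at which 1 of the 3 values shown sits.

The compounds shown leave open whether the 3-methoxy group of compound 2 contributes to the value at all or the 4-methoxy group of compound 3 alone weakens it, a question that a plain phenyl, a 3-hydroxyphenyl or a 4-fluorophenyl at the same nitrogen would address. They also leave open whether the same swap would have a like effect with another group on the shared core, such as a quinoline replaced by the sulfonamide-bearing methoxypyridine of compound 1.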